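Ethylamino in place of pyrrolidin-1-yl: working notes

The source may report more compounds than this note shows. Statements on the series, on what has been measured and on what is new or still open speak of the compounds shown alone.

In a functional assay on MCF7 cells (Homo sapiens) for antiproliferative activity (a lower number here means a stronger inhibitor, a higher number a weaker inhibitor), compound 1 `CC(C)=CCc1cc(C(=O)Nc2cc3ccc(OCC4CCCNC4)c(C)c3oc2=O)ccc1O` gives 790 nM and compound 2 `CC(C)=CCc1cc(C(=O)Nc2cc3ccc(OCCCN4CCCC4)c(C)c3oc2=O)ccc1O` gives 990 nM. These two numbers, the only ones measured so far, lie within the scatter of each other, so compound 2 stands level with compound 1.

Compound 3 `CCNCCCOc1ccc2cc(NC(=O)c3ccc(O)c(CC=C(C)C)c3)c(=O)oc2c1C` carries ethylamino in place of pyrrolidin-1-yl on a saturated chain carbon, three bonds along the chain from an oxygen on an aromatic ring.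

Among the measured compounds shown here, one measured step bears on this change: a 1.3-fold higher number from compound 1 to compound 2 (0.10 log units; within the scatter). It also alters the group carried on that oxygen, and it stays within the scatter. For the measured compounds named here, no measured compound carries ethylamino, so this support is indirect. No step beyond the scatter is expected in this assay.

The estimated step is a 1.2-fold lower number from compound 2 to compound 3 (0.09 log units; within the scatter). Compound 3 is expected at 800 nM, with an estimated range of 350 nM to 1800 nM.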

Compound 3, half-maximal inhibitory concentration: 980 nM
Compound 3: middle estimate off by 1.2-fold (0.09 log units), on the low side; the range from low to high includes it.
By their numbers in this assay, from the lowest: compounds 1, 3 and 2 (each within the scatter of the next).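

In this assay, ethylamino in place of pyrrolidin-1-yl on a saturated chain carbon, three bonds along the chain from an oxygen on an aromatic ring, gives a 1.0-fold lower number from compound 2 to compound 3 (0.00 log units; within the scatter), so this position accepts a group with no ring and with a hydrogen-bond donor without any step beyond the scatter. The change of 2-(ethylamino)ethyl in place of piperidin-3-yl on a saturated chain carbon bound to an oxygen on an aromatic ring gives a 1.2-fold higher number from compound 1 to compound 3 (0.09 log units; within the scatter), which places all three amine-bearing side chains level with one another. Nothing on hand accounts for this flat reading.

The compounds shown leave open whether a hydroxyl or a carboxylic acid in place of ethylamino would keep the number in this range. They also leave open how a longer chain between the oxygen and the amine would read in this assay.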